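Replacing the hydroxymethyl of compound 3 with a pyridyl thioester

A few compounds are considered here, and "the series" means these few. Any claim that something is new, unique, unknown or untested is made for them only; others in the source may bear on it.

Three compounds on the shared pyrrole core carrying a propoxycarbonyl, a tert-butoxycarbonyl and a methyl group have been measured. Compound 1 `CCCOC(=O)c1[nH]c(COC(C)=O)c(C(=O)OC(C)(C)C)c1C` gives 2700 nM in an assay on CHO cells for inhibition of metabotropic glutamate receptor 1 (Rattus norvegicus); a higher number here means a weaker inhibitor, a lower number a stronger inhibitor. Compound 2 `C=CCOC(=O)Cn1c(C)c(C(=O)OC(C)(C)C)c(C)c1C(=O)OCCC` gives 12600 nM in this assay, and compound 3 `CCCOC(=O)c1[nH]c(CO)c(C(=O)OC(C)(C)C)c1C` gives 7900 nM in this assay. Compound 3 thus has the second highest of the three numbers; its value sits within the scatter of compound 2, while the gap to compound 1 is beyond it: a 2.9-fold higher number from compound 1 to compound 3 (0.47 log units; beyond the scatter).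

Compound 4 `CCCOC(=O)c1[nH]c(C(=O)Sc2ccccn2)c(C(=O)OC(C)(C)C)c1C` is the next step from compound 3, with ((pyridin-2-yl)sulfanyl)carbonyl in place of hydroxymethyl on an aromatic carbon. Going by the values given here, no measured pair shows exactly this exchange. Among the compounds with values here, the only step that touches this position is the one from compound 1 to compound 3, where the free hydroxyl gave the higher number, so a carbonyl-bearing group at this carbon has so far gone with a lower number than the hydroxymethyl. On that basis a modest move toward a lower number is expected for compound 4, a 3.2-fold lower number from compound 3 to compound 4 (0.50 log units; beyond the scatter), though the new group is much larger than anything measured here. Compound 4 is therefore estimated at 2500 nM in this assay, with a range from 600 nM to 10000 nM.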

Compound 4, half-maximal inhibitory concentration: 3200 nM
Compound 4: middle estimate off by 1.3-fold (0.11 log units), on the low side; low and high end bracket the measured number.
By their numbers in this assay, from the lowest: compounds 1 and 4 (each within the scatter of the next); then compounds 3 and 2 (each within the scatter of the next).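

In this assay, the aromatic carbon next to the ring nitrogen accepts a group carrying a six-membered aromatic ring without any rise in the number, and the exchange for hydroxymethyl gives a 2.5-fold lower number from compound 3 to compound 4 (0.39 log units; beyond the scatter) as its step. Set against acetoxymethyl, the same group gives a 1.2-fold higher number from compound 1 to compound 4 (0.07 log units; within the scatter) as its step, so these two quite different groups cannot be told apart at this position, while hydroxymethyl stands apart from both with the higher number. Nothing available bears on what lies behind these steps.

The compounds shown leave open which part of ((pyridin-2-yl)sulfanyl)carbonyl accounts for the step from hydroxymethyl: the carbonyl, the sulfur or the pyridine ring. On these data alone, a carboxylic acid, an amide or a phenyl thioester at this carbon would separate these parts, and whether an amine on a longer chain would match hydroxymethyl or the two lower-number groups is equally open.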